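The source may hold more compounds than are shown below. What is called first, only, known or untested is meant among the compounds shown, and "the series" means these compounds.

Measured in a functional assay on the whole organism with Mus musculus as the target; a higher number here means that more compound is needed for the effect, a lower number that less compound is needed:
- compound 1 `CNC(=O)/C=C1\CCc2c(F)cc(F)cc21`: 45 mg/kg
- compound 2 `NC(=O)/C=C1\CCc2cc(F)cc(F)c21`: 44 mg/kg

Compound 1 at 45 mg/kg and compound 2 at 44 mg/kg lie within the scatter of each other, so these two numbers set no order between them. Compound 3 `CC(C)NC(=O)/C=C1\CCc2c(F)cc(F)cc21` is still unmeasured. It carries isopropyl in place of methyl on an amide-type nitrogen of compound 1: isopropyl in place of methyl on an amide-type nitrogen. Among the measured compounds shown here, no measured pair shows this change, so any expectation in this assay is weakly founded. A modest rise in the number is expected, meaning more compound needed, and a step within the scatter would remain quite possible. The estimated step runs a 1.3-fold higher number from compound 1 to compound 3 (0.12 log units; within the scatter). For compound 3 the estimated value is 60 mg/kg, with an expected range of 25 mg/kg to 140 mg/kg.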

Compound 3, dose for half-maximal effect: 50 mg/kg
Compound 3: the middle estimate sits 1.2-fold (0.08 log units) above what was measured, and the stated range covers the measured number.
By their numbers in this assay, from the lowest: compounds 2, 1 and 3 (each within the scatter of the next).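

In this assay, isopropyl in place of methyl on an amide-type nitrogen gives a 1.1-fold higher number from compound 1 to compound 3 (0.05 log units; within the scatter), so this single pair sets no order between the two compounds. Among the compounds shown here, at this position, the methylcarbamoyl to isopropylcarbamoyl change therefore produces no step beyond the scatter, which is the first reading of any change here, though it rests on one pair only. No measured evidence bears on this result.

Still open, as far as these compounds go, is whether a longer chain, a cyclopropyl or a benzyl group on the same nitrogen would produce a step beyond the scatter. Also open, from the compounds shown here alone, is how a carboxylic acid in place of the whole methylcarbamoyl group would read in this assay.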